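From a formylphenyl to a naphthyl on the shared core

The source may hold more compounds than are shown below. What is called first, only, known or untested is meant among the compounds shown, and "the series" means these compounds.

Compound 1 is `c1ccc(-c2cn3ccnc3c(-c3ccc4ncn(C5CCCCC5)c4c3)n2)cc1`; in a functional assay on SF-295 cells (Homo sapiens) for inhibition, read by sulforhodamine B assay, with a stated time of 48 h, tested at 10 uM (a lower number here means less inhibition, a higher number more inhibition at the concentration tested (going by the name of the read-out)), compound 1 gives 39.8%.
Compound 2 is `COc1ccc(-c2cn3ccnc3c(-c3ccc4ncn(C5CCCCC5)c4c3)n2)cc1`; in this assay compound 2 gives 92.5%.
Compound 3 is `O=Cc1ccc(-c2cn3ccnc3c(-c3ccc4ncn(C5CCCCC5)c4c3)n2)cc1`; in this assay compound 3 gives 23.1%.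

Compound 3 stands lowest of the three measured numbers. Its nearest neighbour is compound 1, and the difference is a number 16.7 percentage points lower from compound 1 to compound 3 (beyond the scatter), so compound 1 sits above it by a modest amount. Compound 2 is furthest away: a number 69.4 percentage points lower from compound 2 to compound 3 (beyond the scatter).

Compound 4 is `c1ccc2c(-c3cn4ccnc4c(-c4ccc5ncn(C6CCCCC6)c5c4)n3)cccc2c1`. The change from compound 3 is naphthalen-1-yl in place of 4-formylphenyl on an aromatic carbon.

Among the measured compounds shown here, only one measured step touches this change, and only in part: a number 16.7 percentage points lower from compound 1 to compound 3 (beyond the scatter) shows what the formyl group adds when it replaces hydrogen on that phenyl. Undoing it would be expected to bring compound 4 back to roughly the level of compound 1. For the measured compounds named here, for the second aromatic ring that naphthalen-1-yl brings, no measured compound gives any guidance, so the range must be wide. Compound 4 is therefore expected to give about 38% in this assay, between 15% and 65%. The expected step is a number 14.9 percentage points higher from compound 3 to compound 4 (beyond the scatter), a modest rise that may not clear the scatter.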

Compound 4, a percentage reported as inhibition, at one concentration (the size of the read-out at that concentration, not a potency): 6.34%
Compound 4: middle estimate off by 31.7 percentage points, on the high side, and the stated range ends above it.
By their numbers in this assay, from the lowest: compound 4; then compound 3; then compound 1; then compound 2.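

With naphthalen-1-yl the change reaches the ring itself rather than a substituent on the phenyl, and in this assay the outcome is a number 33.5 percentage points lower from compound 1 to compound 4 (beyond the scatter) and also a number 16.8 percentage points lower from compound 3 to compound 4 (beyond the scatter). The comparison with the 4-methoxyphenyl group is sharper still, at a number 86.2 percentage points lower from compound 2 to compound 4 (beyond the scatter), which puts compound 4 lowest of the four and shows that this position does not reward every larger aromatic group: compound 2, with the larger 4-methoxyphenyl, stands well above compound 1, whereas compound 4, with its second six-membered aromatic ring, stands well below it. No measurement among these compounds explains why the fused ring lowers the number.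

The compounds shown leave open whether the high number of compound 2 belongs to methoxy in particular, or whether an amine, a hydroxyl group or a longer ether chain such as ethoxy on the same phenyl would also raise it. They also leave open whether naphthalen-2-yl, attached through the other ring carbon, would fall as low as naphthalen-1-yl does on the shared core.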